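The source may report more compounds than this note shows. Statements on the series, on what has been measured and on what is new or still open speak of the compounds shown alone.

In a functional assay on MIA PaCa-2 cells (Homo sapiens) for cytotoxicity, read by fluorescence, with a stated time of 48 h (on this read-out higher numbers stand for an effect only at larger amounts of compound and lower numbers for an effect already at smaller amounts), compound 1 `CC(C)=CCC/C(C)=C/CC/C(C)=C/CSC[C@H](NC(=O)CCCCCN1CCCC1)C(=O)NC1CCCCC1` gives 5600 nM. Compound 2 `CC(C)=CCC/C(C)=C/CC/C(C)=C/CSC[C@H](NC(=O)CCCCCN1CCCC1)C(=O)NC1CCCC1` gives 3200 nM, and a 1.8-fold lower number from compound 1 to compound 2 (0.24 log units; within the scatter) means the two cannot be told apart. Compound 3 `CC(C)=CCC/C(C)=C/CC/C(C)=C/CSC[C@H](NC(=O)CCCCCN1CCCC1)C(=O)N1CCCCC1` gives 12400 nM, with a 2.2-fold higher number from compound 1 to compound 3 (0.35 log units; beyond the scatter) and a 3.9-fold higher number from compound 2 to compound 3 (0.59 log units; beyond the scatter). Compound 4 `CC(C)=CCC/C(C)=C/CC/C(C)=C/CSC[C@H](NC(=O)CCCCCN1CCN(C)CC1)C(=O)NC1CCCCC1` differs from compound 1 in one place: 4-methylpiperazin-1-yl in place of pyrrolidin-1-yl on a saturated chain carbon, five bonds along the chain from a carbonyl carbon. That is 4-methylpiperazin-1-yl in place of pyrrolidin-1-yl on a saturated chain carbon, five bonds along the chain from a carbonyl carbon. All three measured steps change the amide group instead, so none tests this swap directly, and the data give no direction for it. They show only how large steps in this small set have been. No step beyond the scatter is expected, and the estimated step is a 1.1-fold higher number from compound 1 to compound 4 (0.03 log units; within the scatter). For compound 4 the estimate is 6000 nM, with an expected range of 2500 nM to 15000 nM.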

Compound 4, half-maximal effective concentration: 5900 nM
Compound 4: middle estimate off by 1.0-fold (0.01 log units), on the high side; the range from low to high includes it.
By their numbers in this assay, from the lowest: compounds 2, 1 and 4 (each within the scatter of the next); then compound 3.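

Within the data shown here, the earlier compounds varied only the amide end, so this is the first look at the amine end of the molecule, on a saturated chain carbon, five bonds along the chain from a carbonyl carbon. In this assay, replacing pyrrolidin-1-yl with 4-methylpiperazin-1-yl gives a 1.1-fold higher number from compound 1 to compound 4 (0.02 log units; within the scatter) and shows that this position tolerates the six-membered ring with its added nitrogen. Nothing available explains this result. Going by these compounds, whether a morpholin-4-yl group, a dimethylamino group or a hydroxyl group would be tolerated here remains open. So does the effect of a shorter or longer chain.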